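A few compounds are considered here, and "the series" means these few. Any claim that something is new, unique, unknown or untested is made for them only; others in the source may bear on it.

Three compounds share one core and differ only in the group attached to an aromatic carbon at one end. Compound 3 `CC1=C(/C=C/C(=O)/C=C/c2ccccc2[N+](=O)[O-])C(C)(C)CCC1` carries a nitro group there. Going by the values given here, in a functional assay on PC-3 cells (Homo sapiens) for cytotoxicity, read by sulforhodamine B assay, with a stated time of 48 h (a higher number here means a weaker inhibitor, a lower number a stronger inhibitor), compound 3 gives 9500 nM, the lowest of the three numbers measured so far, yet neither of the other two is separated from it beyond the scatter: compound 2 `COc1ccccc1/C=C/C(=O)/C=C/C1=C(C)CCCC1(C)C` gives 14200 nM, and compound 1 `CC1=C(/C=C/C(=O)/C=C/c2ccc(Br)cc2)C(C)(C)CCC1` gives 18900 nM. Within these three, then, no ordering can be claimed.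

Compound 4 `CC1=C(/C=C/C(=O)/C=C/c2ccccc2C)C(C)(C)CCC1` is compound 3 with a single change: methyl in place of nitro on an aromatic carbon. Among the compounds with values here, only one measured step concerns an exchange of groups at that same place: a 1.5-fold lower number from compound 2 to compound 3 (0.17 log units; within the scatter), a swap that left the number where it was, within the scatter. Within the data shown here, for compound 1 and compound 3 no single step is defined; their two values are simply close to each other. A swap of one small group for another on this carbon has therefore so far produced nothing beyond the scatter, and the same is expected here: the step of a 1.3-fold higher number from compound 3 to compound 4 (0.10 log units; within the scatter) is estimated to stay within the scatter, in no clear direction. Compound 4 is accordingly expected to give about 12000 nM in this assay, with a range from 5000 nM to 30000 nM.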

Compound 4, half-maximal inhibitory concentration: 44100 nM
Estimate against measurement, compound 4: 3.7-fold (0.57 log units) below; measured number above the stated range.
By their numbers in this assay, from the lowest: compounds 3, 2 and 1 (each within the scatter of the next); then compound 4.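

In this assay, going by these compounds alone, the group on this aromatic carbon, ortho to a large group, now makes a difference that can be read: methyl in place of nitro gives a step beyond the scatter (a 4.6-fold higher number from compound 3 to compound 4 (0.67 log units; beyond the scatter)), which no exchange among the earlier compounds had done. Methyl in place of methoxy at the same carbon also passes the scatter (a 3.1-fold higher number from compound 2 to compound 4 (0.49 log units; beyond the scatter)), so methyl stands apart from both of these groups, although nitro and methoxy cannot be told apart from each other. The larger exchange of 2-methylphenyl in place of 4-bromophenyl points the same way (a 2.3-fold higher number from compound 1 to compound 4 (0.37 log units; beyond the scatter)), which makes compound 4 the weakest of the four inhibitors, though each of its steps is only modest in size.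

From the compounds shown here alone, with only nitro, methoxy and methyl compared at this carbon, it stays open how an amine, a carboxylic acid or a longer chain there would read in this assay, and whether any such group would take the number clearly below that of compound 3. No measurement shown here bears on why methyl differs from nitro and methoxy at this carbon.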